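Alpha-ketooxazole series: tetrazole to thiomorpholine amide

This account rests on a few compounds, and the source may have more. Where it says the series, first, only, none or still open, it means among the compounds named here.

Within the data shown here, compound 2 `O=C(CCCCCCc1ccccc1)c1ncc(-c2nnn[nH]2)o1` gives 63 nM in an assay (Rattus norvegicus) for inhibition of Fatty-acid amide hydrolase 1 (Homo sapiens) (a lower number here means a stronger inhibitor, a higher number a weaker inhibitor), the lowest of the two numbers so far; compound 1 `O=C(CCCCCCc1ccccc1)c1ncc(-c2ccc(O)cc2)o1` gives 140 nM. Among the measured compounds shown here, the only measured step, a 2.2-fold lower number from compound 1 to compound 2 (0.35 log units; beyond the scatter), concerns a different change and does not bear on the one at hand. Compound 3 `O=C(CCCCCCc1ccccc1)c1ncc(C(=O)N2CCSCC2)o1` differs from compound 2 by (thiomorpholin-4-yl)carbonyl in place of 1H-tetrazol-5-yl on an aromatic carbon. For the measured compounds named here, with no comparable step to lean on, the direction is open; a modest weakening is expected, a 2.4-fold higher number from compound 2 to compound 3 (0.38 log units; beyond the scatter). Compound 3 is therefore estimated at 150 nM, within 40 nM to 600 nM.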

Compound 3, inhibition constant: 10 nM
The estimate for compound 3 lay 15-fold (1.18 log units) above the measured number; measured number outside the range, below it.
By their numbers in this assay, from the lowest: compound 3; then compound 2; then compound 1.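

On this aromatic carbon next to the ring oxygen, (thiomorpholin-4-yl)carbonyl gives the lowest number of the three in this assay, with a 6.3-fold lower number from compound 2 to compound 3 (0.80 log units; beyond the scatter) and a 14-fold lower number from compound 1 to compound 3 (1.15 log units; beyond the scatter). An aromatic ring at this position is therefore not required for a low number, and neither is a hydrogen-bond donor in the group. No measurement here accounts for the gain.

As far as these compounds go, whether the ring sulfur contributes remains open, and (morpholin-4-yl)carbonyl at this carbon would test that. So does the role of the ring itself, which a dimethylamide or a carboxylic acid in its place would address.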